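This account rests on a few compounds, and the source may have more. Where it says the series, first, only, none or still open, it means among the compounds named here.

Compound 1 `C=C1C(=O)[C@@]23C(=O)OC[C@]4([C@@H](OC(C)=O)CCC(C)(C)[C@H]4C=O)[C@@H]2CC[C@H]1[C@H]3OC(=O)c1ccc([N+](=O)[O-])cc1` and compound 2 `C=C1C(=O)[C@@]23C(=O)OC[C@]4([C@@H](OC(C)=O)CCC(C)(C)[C@H]4C=O)[C@@H]2CC[C@H]1[C@H]3OC(=O)c1ccccc1` share one core and differ only in the aromatic ester attached to it. In a functional assay on K562 cells (Homo sapiens) for inhibition, read by MTT assay (on this read-out higher numbers stand for weaker inhibition and lower numbers for stronger inhibition), compound 1 gives 1140 nM, and compound 2 gives 1400 nM. Compound 1 holds the lowest of these two numbers, yet the step of a 1.2-fold higher number from compound 1 to compound 2 (0.09 log units; within the scatter) stays within the scatter, so the two compounds cannot truly be told apart. Compound 3 `C=C1C(=O)[C@@]23C(=O)OC[C@]4([C@@H](OC(C)=O)CCC(C)(C)[C@H]4C=O)[C@@H]2CC[C@H]1[C@H]3OC(=O)c1ccccc1Cl` has not been measured; relative to compound 1 it carries 2-chlorophenyl in place of 4-nitrophenyl on a carbonyl carbon. Among the compounds with values here, the only measured step bearing on a change at this ring is the one from compound 1 to compound 2, where replacing nitro with hydrogen left the number essentially unchanged; nothing measured speaks to a chlorine on this ring. The change is therefore expected to be small, a 1.1-fold higher number from compound 1 to compound 3 (0.06 log units; within the scatter), with no clear direction. Compound 3 is estimated to give 1300 nM in this assay, with a likely range from 500 nM to 3500 nM.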

Compound 3, half-maximal inhibitory concentration: 390 nM
Estimate against measurement, compound 3: 3.3-fold (0.52 log units) above, and the stated range ends above it.
By their numbers in this assay, from the lowest: compound 3; then compounds 1 and 2 (each within the scatter of the next).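

The ester on the shared core is not indifferent to what its ring carries: in this assay, chloro in place of hydrogen gives a 3.6-fold lower number from compound 2 to compound 3 (0.56 log units; beyond the scatter) and counts as a modest change. Hydrogen in place of nitro had given only a 1.2-fold higher number from compound 1 to compound 2 (0.09 log units; within the scatter) and so had shown no readable effect at this ring. The full swap of 4-nitrophenyl for 2-chlorophenyl gives a 2.9-fold lower number from compound 1 to compound 3 (0.47 log units; beyond the scatter) and confirms that this position can respond. Nothing available explains why the chlorine-bearing ring gives the lower number.

On these data alone, whether the result depends on chlorine itself or on where it sits on the ring remains open. So does the outcome with fluorine, bromine, a methoxy group or an amine on the ring.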